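Fluoro in Place of Methoxy on the Benzyl Group

The source may report more compounds than this note shows. Statements on the series, on what has been measured and on what is new or still open speak of the compounds shown alone.

Compound 1, `CCCCCCCC/N=c1\nc(N)c2ncn(Cc3ccccc3)c2c(N)n1`: 4980 nM
Compound 2, `CCCCCCCC/N=c1\nc(N)c2ncn(Cc3ccc(OC)cc3)c2c(N)n1`: 3750 nM

Both numbers come from a functional assay on OVCAR-3 cells (Homo sapiens) for antiproliferative activity, read by WST assay, with a stated time of 72 h; a lower number here means a stronger inhibitor, a higher number a weaker inhibitor. Compound 2 has the lowest of the two, but the step between the two is a 1.3-fold lower number from compound 1 to compound 2 (0.12 log units; within the scatter), so the two cannot be told apart. Compound 3, `CCCCCCCC/N=c1\nc(N)c2ncn(Cc3ccc(F)cc3)c2c(N)n1`, keeps the shared core and changes only this: fluoro in place of methoxy on an aromatic carbon. Among the compounds with values here, the one measured step that touches this position, a 1.3-fold lower number from compound 1 to compound 2 (0.12 log units; within the scatter), stayed within the scatter, so a small step is expected here too, with no clear direction. Compound 3 is therefore expected to give 4500 nM, between 2000 nM and 10000 nM, that is a 1.2-fold higher number from compound 2 to compound 3 (0.08 log units; within the scatter).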

Compound 3, half-maximal inhibitory concentration: 4300 nM
Compound 3: middle estimate off by 1.0-fold (0.02 log units), on the high side; measured number inside the range.
By their numbers in this assay, from the lowest: compounds 2, 3 and 1 (each within the scatter of the next).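

In this assay the fluoro group of compound 3 cannot be told apart from methoxy (a 1.1-fold higher number from compound 2 to compound 3 (0.06 log units; within the scatter)) or from hydrogen (a 1.2-fold lower number from compound 1 to compound 3 (0.06 log units; within the scatter)). On this aromatic carbon, three different substituents now lie within the scatter of one another, so the position looks tolerant of these swaps, a picture that one step alone could not give. No outside data offer an explanation for this. From the compounds shown here alone, whether an amine or a carboxylic acid on this carbon would shift the number stays open, as does the effect of changes elsewhere on the shared core.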